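Adding a chloro to the phenyl of compound 2

The compounds below may be only part of what the source reports. "The series", "measured", "known", "first", "only" and "open" are said of these compounds alone.

Going by the values given here, in a functional assay on HL-60 cells (Homo sapiens) for inhibition, read by MTT assay, with a stated time of 72 h (a higher number here means a weaker inhibitor, a lower number a stronger inhibitor), compound 2 `Cc1ccc(C)c(N2CCN(C(=O)c3oc(C)nc3-c3ccccc3)CC2)c1` gives 31.3 nM as the lower of two numbers so far, while compound 1 `Cc1nc(-c2ccccc2)c(C(=O)N2CCN(c3cccc(Cl)c3Cl)CC2)o1` gives 133 nM as the higher one. Compound 3 `Cc1ccc(C)c(N2CCN(C(=O)c3oc(C)nc3-c3ccccc3Cl)CC2)c1` differs from compound 2 by phenyl to 2-chlorophenyl, with chloro in place of hydrogen on an aromatic carbon as the count. Among the compounds with values here, the only measured step, a 4.2-fold lower number from compound 1 to compound 2 (0.63 log units; beyond the scatter), changed a different group, so it offers a rough size for one change but no direction here. The expected step is a 1.1-fold higher number from compound 2 to compound 3 (0.05 log units; within the scatter) in this assay, possibly none beyond the scatter. For compound 3 the estimate is 35 nM, with an expected range from 12 nM to 100 nM.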

Compound 3, half-maximal inhibitory concentration: > 1000 nM
Compound 3: no number, only a limit; the forecaster's own chance of this, stated with the estimate: 3%; middle value at least 28-fold (1.45 log units) from the limit.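

In this assay one chloro on the phenyl, ortho to a large group, gives an at least 31-fold higher number from compound 2 to compound 3 (1.50 log units; beyond the scatter), a large loss of inhibition. Compound 1 and compound 2 differ only in the group on the ring's amine nitrogen, so they said nothing about this phenyl, which now proves sensitive to one added atom. The value of compound 3 is a limit and not a number: the limit of > 1000 nM in this assay, at which 1 of the 3 values shown sits.

On these data alone, whether the loss belongs to chloro itself or to this position stays open. A fluoro or a methyl at the same place, or a chloro elsewhere on the phenyl, would separate the two.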